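This account rests on a few compounds, and the source may have more. Where it says the series, first, only, none or still open, it means among the compounds named here.

Compound 1 `Cc1ccc(-c2c(C#N)[n+]([O-])c3cc(F)ccc3[n+]2[O-])cc1` and compound 3 `COC(=O)c1ccc(-c2c(C#N)[n+]([O-])c3cc(F)ccc3[n+]2[O-])cc1` share the same core and differ only at the group on the pendant ring, where compound 3 carries methoxycarbonyl in place of methyl on an aromatic carbon. In an ADME assay on Vero cells (Chlorocebus sabaeus) for cytotoxicity, read by MTT assay, with a stated time of 72 h (on this read-out higher numbers stand for weaker inhibition and lower numbers for stronger inhibition), compound 1 gives 14.6 ug/mL, and compound 3 gives 57.5 ug/mL, a step of a 3.9-fold higher number from compound 1 to compound 3 (0.60 log units; beyond the scatter). Compound 2 `Cc1ccc(-c2c(C#N)[n+]([O-])c3cc(Cl)ccc3[n+]2[O-])cc1` is compound 1 with chloro in place of fluoro on an aromatic carbon. In this assay compound 2 gives 0.63 ug/mL, a step of a 23-fold lower number from compound 1 to compound 2 (1.37 log units; beyond the scatter). Compound 4 `COC(=O)c1ccc(-c2c(C#N)[n+]([O-])c3cc(Cl)ccc3[n+]2[O-])cc1` is not yet measured; it differs from compound 3 by chloro in place of fluoro on an aromatic carbon, which is the same change at the same place as that from compound 1 to compound 2. If that change carries over, the step from compound 3 to compound 4 is expected to be large, though the only precedent, a 23-fold lower number from compound 1 to compound 2 (1.37 log units; beyond the scatter), comes from a single pair, so a somewhat smaller step is allowed for in the estimate, a 16-fold lower number from compound 3 to compound 4 (1.22 log units; beyond the scatter). On this basis compound 4 is expected to give about 3.5 ug/mL in this assay, estimated to lie between 0.8 ug/mL and 15 ug/mL.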

Compound 4, half-maximal inhibitory concentration: 20.9 ug/mL
The estimate for compound 4 lay 6.0-fold (0.78 log units) below the measured number; the whole stated range lies below it.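

In this assay, chloro in place of fluoro kept its direction on the methoxycarbonyl core but not its size, giving a 2.8-fold lower number from compound 3 to compound 4 (0.44 log units; beyond the scatter), so the step seen on the methyl core cannot simply be carried across: the same change on two cores in this assay, a 23-fold lower number (1.37 log units; beyond the scatter) from compound 1 to compound 2 and a 2.8-fold lower number (0.44 log units; beyond the scatter) from compound 3 to compound 4, 8.4-fold (0.93 log units) apart, beyond the scatter of two such steps

Read from the other side, methoxycarbonyl in place of methyl gives a 33-fold higher number from compound 2 to compound 4 (1.52 log units; beyond the scatter), and this step also depends on the core: the same change on two cores in this assay, a 3.9-fold higher number (0.60 log units; beyond the scatter) from compound 1 to compound 3 and a 33-fold higher number (1.52 log units; beyond the scatter) from compound 2 to compound 4, 8.4-fold (0.93 log units) apart, beyond the scatter of two such steps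

Both comparisons rest on the same four compounds, so they show that the two changes do not add up in this one set, but they do not show why, or how the halogen change would behave with any other group on the pendant ring.

Going by these compounds, it remains open whether the large step belongs to the methyl compounds alone or would recur with an amine or a carboxylic acid on the pendant ring. On these data alone, it is equally open how bromo or a methoxy group would compare with chloro and fluoro at that place on the shared core.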